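The compounds below may be only part of what the source reports. "The series", "measured", "known", "first", "only" and "open" are said of these compounds alone.

Measured compounds:
- compound 1, `CC1(C)[C@H]2CC[C@]1(C)N(Cc1cn(-c3cccc(F)c3)nn1)C(=O)C2`, 220 nM
- compound 2, `CC1(C)[C@H]2CC[C@]1(C)N(Cc1cn(-c3cccc(Cl)c3)nn1)C(=O)C2`, 260 nM

These two compounds were tested in a functional assay on PANC-1 cells (Homo sapiens) for inhibition, read by MTT assay, with a stated time of 24 h; on this read-out lower numbers stand for stronger inhibition and higher numbers for weaker inhibition. Compound 1 gives 220 nM, the lower of the two numbers, with compound 2 at 260 nM. Going by the values given here, the only measured step, a 1.2-fold higher number from compound 1 to compound 2 (0.07 log units; within the scatter), swaps chloro for fluoro on an aromatic carbon and stays within the scatter, so the two compounds cannot be ranked.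

Compound 3, `Cc1ccccc1-n1cc(CN2C(=O)C[C@@H]3CC[C@@]2(C)C3(C)C)nn1`, has not yet been measured. It differs from compound 1 in the group on the ring nitrogen: 2-methylphenyl in place of 3-fluorophenyl on an aromatic nitrogen. Among the compounds with values here, this change moves the substituent to another position on the phenyl ring and exchanges a halogen for a methyl group, which is a different kind of change than the one step seen so far. That step, a 1.2-fold higher number from compound 1 to compound 2 (0.07 log units; within the scatter), bears on it only in showing that a small change on this phenyl ring left the number in this assay essentially unchanged. Without closer precedent, no step beyond the scatter is expected for compound 3: the estimate is a 1.2-fold higher number from compound 1 to compound 3 (0.07 log units; within the scatter). Compound 3 is therefore expected to give about 260 nM, within a range from 110 nM to 650 nM.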

Compound 3, half-maximal inhibitory concentration: 250 nM
Compound 3: middle estimate off by 1.0-fold (0.02 log units), on the high side, and the stated range covers the measured number.
By their numbers in this assay, from the lowest: compounds 1, 3 and 2 (each within the scatter of the next).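

Until now, only one halogen swapped for another on the phenyl ring had been seen. Compound 3 shows that the number in this assay also stays within the scatter when 3-fluorophenyl gives way to 2-methylphenyl on the aromatic nitrogen (a 1.1-fold higher number from compound 1 to compound 3 (0.06 log units; within the scatter)), a change that alters both the kind of substituent and its place on the phenyl ring. The comparison with 3-chlorophenyl reads the same way (a 1.0-fold lower number from compound 2 to compound 3 (0.02 log units; within the scatter)), so among these three compounds a halogen on the phenyl ring is not needed for a number in this range, and no measurement at hand explains why the three groups read alike.

From the compounds shown here alone, all three groups are phenyl rings with a single small substituent, so it remains open whether the number would hold with something quite different on that nitrogen, such as a pyridine ring, a benzyl group, or a phenyl ring carrying an amine or a carboxylic acid. Going by these compounds, because the substituent and its position changed together in compound 3, the effect of each alone also remains open, and a 3-methylphenyl or 2-fluorophenyl group would separate the two.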